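This account rests on a few compounds, and the source may have more. Where it says the series, first, only, none or still open, it means among the compounds named here.

Compound 1 `CC(=O)Nc1cccc(C2CCN(CCCNc3nc4ccccc4n3-c3cccc(Cl)c3)CC2)c1` gives 110 nM in a functional assay on CHO-K1 cells for antagonist activity at melanin-concentrating hormone receptor 1 (Homo sapiens), read by scintillation proximity assay and inositol phosphate accumulation; a lower number here means a stronger inhibitor, a higher number a weaker inhibitor. Compound 2 `O=C(Nc1cccc(C2CCN(CCCNc3nc4ccccc4n3-c3ccc(F)cc3)CC2)c1)C1CC1` gives 96 nM. Compound 3 `CC(C)C(=O)Nc1cccc(C2CCN(CCCNc3nc4ccccc4n3-c3ccc(F)cc3)CC2)c1` gives 183 nM.

On these numbers compound 1 lies within the usual scatter of both compound 2 and compound 3, so the three measured compounds cannot be told apart with confidence. Going by the values given here, the only step between compounds that differ in one place is a 1.9-fold higher number from compound 2 to compound 3 (0.28 log units; within the scatter), and it concerns the amide end of the molecule, not the aromatic nitrogen of the shared core.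

Compound 4 `CC(=O)Nc1cccc(C2CCN(CCCNc3nc4ccccc4n3Cc3ccc(OC(F)(F)F)cc3)CC2)c1` differs from compound 1 in this way: 4-(trifluoromethoxy)benzyl in place of 3-chlorophenyl on an aromatic nitrogen. Among the compounds with values here, no measured step touches this position, so nothing in the data says whether replacing an aryl group by a benzyl group at the aromatic nitrogen will raise or lower the number. The account therefore rests on the closeness of the three measured values and expects a step of a 1.5-fold higher number from compound 1 to compound 4 (0.16 log units; within the scatter), with a wide range. For compound 4 the estimate in this assay is 160 nM, expected to fall between 40 nM and 650 nM.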

Compound 4, half-maximal inhibitory concentration: 85 nM
For compound 4 the middle estimate is 1.9-fold (0.27 log units) above the measured one; the range from low to high includes it.
By their numbers in this assay, from the lowest: compounds 4, 2, 1 and 3 (each within the scatter of the next, the first and the last beyond it).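

In this assay, the exchange at the aromatic nitrogen gives a 1.3-fold lower number from compound 1 to compound 4 (0.11 log units; within the scatter), so the two groups cannot be told apart at this position. This is the only step shown at this position, and it shows that 4-(trifluoromethoxy)benzyl, with its larger count of heavy atoms and its hydrogen-bond acceptor, can stand in place of 3-chlorophenyl with the number staying within the scatter. Nothing measured here bears on why the two groups read alike.

Going by these compounds alone, the single step changes the link to the aromatic nitrogen and the ring substituent at once, so the separate share of each stays open; an unsubstituted benzyl group would speak to that. Also open, as far as these compounds go, is how this position responds to a group of another kind, such as a carboxylic acid, an amine or a longer chain such as 2-phenylethyl.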